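The source may hold more compounds than are shown below. What is called first, only, known or untested is meant among the compounds shown, and "the series" means these compounds.

Measured compounds:
compound 1 `CC(C)N1CCN(c2cccc3c2C[C@H](CN(C)[C@H]2CCCc4cccnc42)NC3)CC1` — 143 nm/s
compound 2 `CN1CCN(c2cccc3c2C[C@H](CN(C)[C@H]2CCCc4cccnc42)NC3)CC1` — 996 nm/s

The two measured compounds share one core and differ only at the amine nitrogen in the ring attached to the aromatic carbon. In an ADME assay for permeability, using PAMPA, at pH 7.4 (a lower number here means that the compound crosses the layer more slowly, a higher number that the compound crosses the layer faster), compound 1 gives 143 nm/s, while compound 2 gives 996 nm/s. Among the compounds with values here, the one step between them, a 7.0-fold higher number from compound 1 to compound 2 (0.84 log units; beyond the scatter), shows that the smaller group on that nitrogen goes with the higher number. Compound 2 therefore stands at the top of the two numbers; its nearest neighbour is compound 1, whose number is lower by the same step.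

Compound 3 `CN(C[C@H]1Cc2c(cccc2N2CCN3CCC[C@H]3C2)CN1)[C@H]1CCCc2cccnc21` has not yet been measured in this assay. It differs from compound 2 by a group of 9 heavy atoms (7 carbon, 2 nitrogen; one five-membered non-aromatic ring with 1 hetero atom, one six-membered non-aromatic ring with 2 hetero atoms) in place of a group of 7 heavy atoms (5 carbon, 2 nitrogen; one six-membered non-aromatic ring with 2 hetero atoms), on an aromatic carbon. Within the data shown here, the only measured step that bears on this change is the one from compound 1 to compound 2, where adding two carbons to the group on the ring nitrogen went with a lower number. Compound 3 also adds carbons at that ring, so a step downward in this assay is expected, about a 2.5-fold lower number from compound 2 to compound 3 (0.40 log units; beyond the scatter), though the new group is a ring rather than a branched chain and the size of the effect is uncertain. Compound 3 is thus estimated at 400 nm/s, with a range from 150 nm/s to 1000 nm/s.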

Compound 3, apparent permeability: 167 nm/s
Compound 3: the middle estimate sits 2.4-fold (0.38 log units) above what was measured; measured number inside the range.
By their numbers in this assay, from the lowest: compounds 1 and 3 (each within the scatter of the next); then compound 2.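

In this assay, replacing 4-methylpiperazin-1-yl on the aromatic carbon with the group holding a five-membered and a six-membered non-aromatic ring gives a clear drop (a 6.0-fold lower number from compound 2 to compound 3 (0.78 log units; beyond the scatter)), so the position responds to a change in the ring system itself as well as to a change in the substituent on the ring nitrogen. The two groups of 9 heavy atoms cannot be told apart (a 1.2-fold higher number from compound 1 to compound 3 (0.07 log units; within the scatter)), so the isopropyl-bearing group of compound 1 and the two-ring group of compound 3 read alike here, and among these three compounds only compound 2, with its group of 7 heavy atoms, stands apart, although the hydrogen-bond donor and acceptor counts of the leaving and entering groups are the same. No supporting evidence is available to explain the drop.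

The compounds shown leave open whether the number falls gradually or abruptly between the methyl and isopropyl groups, which an ethyl group on the ring nitrogen would help to settle. They also leave open where a morpholine or an unsubstituted piperazine on the same aromatic carbon would stand, and whether the opposite stereocentre in the two-ring group would read the same as compound 3.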